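Methyl to Trifluoromethyl on an Aromatic-Ring Oxygen

The source may report more compounds than this note shows. Statements on the series, on what has been measured and on what is new or still open speak of the compounds shown alone.

Compound 1, `Cc1cccc(NC(=O)C(Cl)Cl)c1`: "not determined" (no result reported) in a functional assay on BGC-823 cells (Homo sapiens) for antiproliferative activity, read by MTT assay, with a stated time of 72 h; a lower number here means a stronger inhibitor, a higher number a weaker inhibitor.
Compound 2, `COc1cccc(NC(=O)C(Cl)Cl)c1`: 179000 nM in this assay.

In this assay compound 2 gives 179000 nM, and this is the only number shown for the series; for compound 1 the entry reads "not determined" (no result reported), so nothing can be said of its strength. Compound 3, `O=C(Nc1cccc(OC(F)(F)F)c1)C(Cl)Cl`, is the next compound in line. It differs from compound 2 in one place: trifluoromethyl in place of methyl on an oxygen on an aromatic ring. Among the compounds with values here, no step between two measured compounds is available here, so there is no measured pair from which the size of such a change could be read off. Within the data shown here, with only the one value of compound 2 as an anchor, the change from compound 2 to compound 3 is expected to stay close to the scatter, with no clear direction, as the step of a 1.2-fold lower number from compound 2 to compound 3 (0.08 log units; within the scatter) expresses. Compound 3 is therefore expected to give about 150000 nM in this assay, within a range from 40000 nM to 500000 nM.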

Compound 3, half-maximal inhibitory concentration: 142000 nM
The estimate for compound 3 lay 1.1-fold (0.02 log units) above the measured number; measured number inside the range.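

In this assay, within the data shown here, the swap of methyl for trifluoromethyl on this oxygen gives a 1.3-fold lower number from compound 2 to compound 3 (0.10 log units; within the scatter) and so provides the first measured pair. Going from methoxy to trifluoromethoxy adds heavy atoms at this place, yet the two compounds cannot be told apart in this read-out, so this one change shows no measurable effect on the number. No measurement is available that would bear on why the two compounds read alike.

Still open, on these data alone, is whether a different group at this place, such as an amine, a longer ethyl chain or a carboxylic acid, would produce a step beyond the scatter. As far as these compounds go, it is also open whether methoxy and trifluoromethoxy would read as closely on a core other than the one shared here.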